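Nitro on the aromatic ring of compound 1

The source may hold more compounds than are shown below. What is called first, only, known or untested is meant among the compounds shown, and "the series" means these compounds.

Values measured in a functional assay on GC3/MTK- cells (Homo sapiens) for inhibition (on this read-out higher numbers stand for weaker inhibition and lower numbers for stronger inhibition), follow.
Compound 1 `C#CCN(Cc1ccc2nc(C)nc(O)c2c1)c1ccccc1` gives > 10700 nM (a limit)
Compound 2 `C#CCN(Cc1ccc2nc(C)nc(O)c2c1)c1cccc(C(C)O)c1` gives 49000 nM
Compound 3 `C#CCN(Cc1ccc2nc(C)nc(O)c2c1)c1cccc(C(F)(F)F)c1` gives > 4300 nM (a limit)

Compound 1 stands only at a limit (the limit of > 10700 nM in this assay, at which 1 of the 3 values shown sits), so it offers no number to step from. Compound 3 also stands only at a limit (the limit of > 4300 nM in this assay, at which 1 of the 3 values shown sits). Going by the values given here, compound 2 is the only compound with a number (49000 nM).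

Compound 4 `C#CCN(Cc1ccc2nc(C)nc(O)c2c1)c1ccc([N+](=O)[O-])cc1` carries nitro in place of hydrogen on an aromatic carbon, para to a large group (nitro in place of hydrogen on an aromatic carbon). Among the compounds with values here, the steps that bear on this change are the two other replacements of hydrogen on an aromatic carbon (a step that the limit leaves unreadable from compound 1 to compound 2 and a step that the two limits leave unreadable from compound 1 to compound 3). The exchange between those two groups (a step that the limit leaves unreadable from compound 2 to compound 3) adds little, and none of the three has a readable size. No step size can therefore be carried over to compound 4, and no direction is expected with any confidence. The expectation rests on the number for compound 2 (49000 nM). It also rests on compound 1, which gives > 10700 nM, a limit. A further limit is a real possibility. The step is estimated as follows (a step that the limit leaves unreadable from compound 1 to compound 4). In this assay compound 4 is expected at 20000 nM (estimated range 5000 nM to 80000 nM).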

Compound 4, half-maximal inhibitory concentration: 4800 nM
The estimate for compound 4 lay 4.2-fold (0.62 log units) above the measured number, outside the stated range (below it).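

In this assay, nitro para to a large group gives an at least 2.2-fold lower number from compound 1 to compound 4 (0.34 log units; beyond the scatter), so a substituent on this aromatic ring has now produced a change that can be read, and the change is towards stronger inhibition. Going by these compounds alone, the other steps cannot be read, which makes this the only evidence on direction at this ring, and it comes from a single group at a single place. Compound 1 stands only at a limit, so the step is a minimum and its full size remains unknown: the limit of > 10700 nM in this assay, at which 1 of the 4 values shown sits.

As far as these compounds go, whether the lower number belongs to nitro itself or to its place on the ring remains open, as compound 2 and compound 3 differ from compound 4 in more than one place and offer no clean comparison. An amine or a carboxylic acid at the same place, and nitro at another place on the same ring, would help separate the contribution of the group from that of the position.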